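This account rests on a few compounds, and the source may have more. Where it says the series, first, only, none or still open, it means among the compounds named here.

In a functional assay on A549 cells (Homo sapiens) for inhibition, read by sulforhodamine B assay (a higher number here means a weaker inhibitor of growth, a lower number a stronger inhibitor of growth), compound 1 `c1ccc(-c2ccc(-c3ccc(-c4nc5ccccc5[nH]4)cc3)cc2)cc1` gives 41200 nM, compound 2 `Cc1ccc2[nH]c(-c3ccc(-c4ccc(-c5cccc(Cl)c5)cc4)cc3)nc2c1` gives 2800 nM, and compound 3 `Oc1cccc2[nH]c(-c3ccc(-c4ccc(-c5ccccc5)cc4)cc3)nc12` gives 8320 nM, the second highest of the three numbers. Compound 4 `Oc1cccc2[nH]c(-c3ccc(-c4ccc(-c5ccc(OC(F)(F)F)cc5)cc4)cc3)nc12` follows from compound 3 by trifluoromethoxy in place of hydrogen on an aromatic carbon, with trifluoromethoxy in place of hydrogen on an aromatic carbon, para to a large group. Going by the values given here, the only measured single-place step, a 5.0-fold lower number from compound 1 to compound 3 (0.69 log units; beyond the scatter), involves a different substituent, so it gives only a rough scale. Compound 2 differs from compound 3 in more than one place, but compound 2 at 2800 nM shows a lower number within the series. A modest expected move toward lower numbers is a 2.4-fold lower number from compound 3 to compound 4 (0.38 log units; beyond the scatter). The estimate for compound 4 is 3500 nM, with an expected range of 1200 nM to 9500 nM.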

Compound 4, concentration for 50% growth inhibition: 190 nM
Compound 4: the middle estimate sits 18-fold (1.27 log units) above what was measured; the whole stated range lies above it.
By their numbers in this assay, from the lowest: compound 4; then compound 2; then compound 3; then compound 1.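

In this assay, the aromatic carbon para to a large group proves highly responsive: phenyl to 4-(trifluoromethoxy)phenyl gives a 44-fold lower number from compound 3 to compound 4 (1.64 log units; beyond the scatter). This single change moves the number further than the hydroxy change did, at a 5.0-fold lower number from compound 1 to compound 3 (0.69 log units; beyond the scatter). Nothing available accounts for the size of this step. Going by these compounds, whether the effect belongs to trifluoromethoxy specifically or extends to other groups at this position stays open; methoxy, an amine or a carboxylic acid there would test this. Also open, on these data alone, is whether the step holds without the hydroxy group of compound 3.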